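Benzyl replacement for a hydroxy sulfanyl side chain

The source may hold more compounds than are shown below. What is called first, only, known or untested is meant among the compounds shown, and "the series" means these compounds.

Measured compounds:
compound 1, `Nc1nc(O)c2c(n1)n(C1OC(CO)[C@@H](O)[C@H]1O)c(=O)n2C/C=C/c1ccccc1`, 73%
compound 2, `Nc1nc(O)c2c(n1)n(C1OC(CO)[C@@H](O)[C@H]1O)c(=O)n2CC(O)CSc1ccccc1`, 12%

Within the data shown here, in a functional assay on the whole organism (B cells) with Mus musculus as the target (on this read-out higher numbers stand for larger maximal responses and lower numbers for smaller maximal responses), compound 1 gives 73%, and compound 2 gives 12%, the lowest of the two numbers; the single measured step, a number 61 percentage points lower from compound 1 to compound 2 (beyond the scatter), lies beyond the scatter. Compound 3, `COc1ccc(Cn2c(=O)n(C3OC(CO)[C@@H](O)[C@H]3O)c3nc(N)nc(O)c32)cc1`, has not yet been measured in this assay. It differs from compound 2 in one place: 4-methoxyphenyl in place of 1-hydroxy-2-(phenylsulfanyl)ethyl on a saturated chain carbon bound to an aromatic nitrogen. Among the measured compounds shown here, the only step that bears on this change is the one from compound 1 to compound 2, where the side chain on the saturated carbon bound to the aromatic nitrogen was exchanged and the response fell sharply. The group entering in compound 3 resembles that of compound 1 more than that of compound 2, so compound 3 is expected to recover part of the lost response, with an expected step of a number 33 percentage points higher from compound 2 to compound 3 (beyond the scatter). Compound 3 is therefore estimated at 45%, in a range from 10% to 80%.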

Compound 3, largest response reached (reported as maximal response), in percent of the reference or control that the assay uses: 44%
Estimate against measurement, compound 3: 1 percentage points above; the range from low to high includes it.
By their numbers in this assay, from the lowest: compound 2; then compound 3; then compound 1.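

In this assay the exchange of 1-hydroxy-2-(phenylsulfanyl)ethyl for 4-methoxyphenyl gives a number 32 percentage points higher from compound 2 to compound 3 (beyond the scatter) and the exchange of 2-phenylethenyl for the same group gives a number 29 percentage points lower from compound 1 to compound 3 (beyond the scatter) so the response at this position is not limited to the two earlier levels. A third group on the saturated chain carbon bound to an aromatic nitrogen gives a clearly separate intermediate value, which makes this position a graded one among the three compounds. Nothing in the available data explains why the groups fall in this order.

The compounds shown do not separate the contributions of the hydroxyl, the sulfur and the chain within 1-hydroxy-2-(phenylsulfanyl)ethyl. They also leave open how an unsubstituted benzene ring, a carboxylic acid or an amine would read at this position.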